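Compound 4: an estimate from two halogenated neighbours

This account rests on a few compounds, and the source may have more. Where it says the series, first, only, none or still open, it means among the compounds named here.

For the measured compounds named here, in an ADME assay on NIH3T3 cells (Mus musculus) for cytotoxicity, with a stated time of 72 h (on this read-out higher numbers stand for weaker inhibition and lower numbers for stronger inhibition), compound 1 `OC[C@H]1O[C@@H](n2cnc3c(NCc4ccc(F)cc4)ncnc32)[C@H](O)[C@@H]1O` gives 44300 nM as the only exact number. Compound 2 `OC[C@H]1O[C@@H](n2cnc3c(NCc4ccc(Br)cc4)ncnc32)[C@H](O)[C@@H]1O` gives > 166000 nM as a limit of the assay and not as a number. Compound 3 `COc1cccc(CNc2ncnc3c2ncn3[C@@H]2O[C@H](CO)[C@@H](O)[C@H]2O)c1OC` carries the entry "not determined" (no result reported) and so holds no place on the numbers.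

The step to compound 4 `OC[C@H]1O[C@@H](n2cnc3c(NCc4ccc(F)c(Cl)c4)ncnc32)[C@H](O)[C@@H]1O` puts 3-chloro-4-fluorophenyl in place of 2,3-dimethoxyphenyl on a saturated chain carbon bound to a nitrogen on an aromatic ring. With no number at its starting point, this step cannot be given a size or a direction.

Going by the values given here, the one measured step that bears on it is bromo in place of fluoro on an aromatic carbon, which gave an at least 3.7-fold higher number from compound 1 to compound 2 (0.57 log units; beyond the scatter) in this assay and shows that a change of halogen can move the number upward. A single pair sets no rule, and the change here is a different one. Compound 4 is therefore expected to read close to compound 1 or somewhat higher, resting on compound 1 at 44300 nM and on an at least 3.7-fold higher number from compound 1 to compound 2 (0.57 log units; beyond the scatter) as the upward reach. The estimate for compound 4 is 60000 nM (expected range 20000 nM to 170000 nM).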

Compound 4, half-maximal inhibitory concentration: > 166000 nM
Compound 4: only a limit was reported; the forecaster's own chance of this, stated with the estimate: 30%; at least 2.7-fold (0.44 log units) between middle value and limit.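

In this assay, chloro in place of hydrogen on an aromatic carbon gives an at least 3.7-fold higher number from compound 1 to compound 4 (0.57 log units; beyond the scatter), so the number rises with the fluoro kept in place, whereas the earlier step had replaced it. Both halogen changes shown from compound 1 now end at a limit, and compound 1 remains the only compound in the series with an exact number, while compound 3, with no result, neither supports nor opposes this pattern. The step between compound 2 and compound 4 cannot be read, and how far either compound lies past compound 1 stays hidden, with both resting on the same ceiling: the limit of > 166000 nM in this assay, at which 2 of the 4 values shown sit.

The compounds shown leave open whether this upward move belongs to halogens in general or only to these two changes, and whether an amine or a carboxylic acid on the same aromatic ring would move the number in the same direction. Also open, from the compounds shown here alone, is the true size of both rises, which would need exact numbers for compound 2 and compound 4.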